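The source may hold more compounds than are shown below. What is called first, only, known or untested is meant among the compounds shown, and "the series" means these compounds.

Among the measured compounds shown here, the three compounds measured so far share one core and differ only in the group carried on an amine nitrogen. Compound 1 `C=C(C)C(=O)NC(=O)NC1=CS(=O)(=O)O[C@@]12[C@@H](CO[Si](C)(C)C(C)(C)C)O[C@@H](n1cc(C)c(=O)n(C)c1=O)[C@@H]2O[Si](C)(C)C(C)(C)C` gives 20000 nM in a functional assay on HEL cells (Homo sapiens) for cytotoxicity, read by microscopy; a higher number here means that more compound is tolerated, a lower number that less compound is tolerated. For compound 2 `Cc1cn([C@@H]2O[C@H](CO[Si](C)(C)C(C)(C)C)[C@@]3(OS(=O)(=O)C=C3NCC(=O)OCc3ccccc3)[C@H]2O[Si](C)(C)C(C)(C)C)c(=O)n(C)c1=O` this assay reports only a limit, >= 400000 nM. For compound 3 `Cc1cn([C@@H]2O[C@H](CO[Si](C)(C)C(C)(C)C)[C@@]3(OS(=O)(=O)C=C3NCC(=O)C(N)=O)[C@H]2O[Si](C)(C)C(C)(C)C)c(=O)n(C)c1=O` the read-out is likewise a limit, >= 16000 nM, so compound 3 stands at the limit of >= 16000 nM in this assay, at which 1 of the 3 values shown sits, without an exact number. Compound 4 `CCNC(=O)NC1=CS(=O)(=O)O[C@@]12[C@@H](CO[Si](C)(C)C(C)(C)C)O[C@@H](n1cc(C)c(=O)n(C)c1=O)[C@@H]2O[Si](C)(C)C(C)(C)C` carries ethylcarbamoyl in place of (carbamoylcarbonyl)methyl on an amine nitrogen. Of the measured steps, a step that the limit leaves unreadable from compound 1 to compound 3 and a step that the two limits leave unreadable from compound 2 to compound 3 remain unreadable, while an at least 20-fold higher number from compound 1 to compound 2 (1.30 log units; beyond the scatter) shows that the group on this nitrogen can shift tolerance considerably. With so little to go on, compound 4 is expected to land near the values seen so far, at an estimated 30000 nM (range 8000 nM to 150000 nM), which means an expected step that the limit leaves unreadable from compound 3 to compound 4.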

Compound 4, minimum cytotoxic concentration: >= 3200 nM
Compound 4 was reported as a limit; the forecaster's own chance of this, stated with the estimate: 40%; the middle value is on the limit's open side.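

In this assay compound 4 is reported only as a limit, >= 3200 nM. Among the compounds shown here, no step from compound 1, compound 2 or compound 3 to compound 4 can be read. As far as these compounds go, how ethylcarbamoyl compares with the other groups on this nitrogen stays open.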